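The source may report more compounds than this note shows. Statements on the series, on what has been measured and on what is new or still open speak of the compounds shown alone.

Measured compounds:
Compound 1 `O=C(/C=C/c1cccc(NC(=O)c2ccccc2Cl)c1)c1nc2ccccc2[nH]1` — 1280 nM
Compound 2 `COc1cccc(C(=O)Nc2cccc(/C=C/C(=O)c3nc4ccccc4[nH]3)c2)c1` — 3680 nM

In a functional assay on HCT-116 cells (Homo sapiens) for antiproliferative activity, read by MTT assay, with a stated time of 48 h (on this read-out higher numbers stand for weaker inhibition and lower numbers for stronger inhibition), compound 2 gives 3680 nM, the highest of the two numbers shown; its nearest neighbour is compound 1, and the step of a 2.9-fold higher number from compound 1 to compound 2 (0.46 log units; beyond the scatter) lies beyond the scatter. Compound 3 `O=C(/C=C/c1cccc(NS(=O)(=O)c2ccccc2Cl)c1)c1nc2ccccc2[nH]1` has not yet been measured. It differs from compound 2 by (2-chlorophenyl)sulfonyl in place of (3-methoxyphenyl)carbonyl on a nitrogen on an aromatic ring. For the measured compounds named here, only one measured step exists, a 2.9-fold higher number from compound 1 to compound 2 (0.46 log units; beyond the scatter), and it concerns the aryl part alone, exchanging one ring for another while the carbonyl stays. Going by the values given here, no measured pair tests the exchange of a carbonyl for a sulfonyl on that nitrogen, so the effect of that part of the change is unknown. Compound 3 carries the same 2-chlorophenyl as compound 1, whose number is lower than that of compound 2, but the sulfonyl is new. Compound 3 is therefore expected to show a step of a 1.8-fold lower number from compound 2 to compound 3 (0.26 log units; within the scatter) in this assay, with wide uncertainty in both directions. The estimate for compound 3 is 2000 nM, within a range from 500 nM to 8000 nM.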

Compound 3, half-maximal inhibitory concentration: 987 nM
For compound 3 the middle estimate is 2.0-fold (0.31 log units) above the measured one; the range from low to high includes it.
By their numbers in this assay, from the lowest: compounds 3 and 1 (each within the scatter of the next); then compound 2.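

In this assay, for the compounds shown here, compound 1 and compound 3 give the first reading of a carbonyl against a sulfonyl on this nitrogen with the 2-chlorophenyl held constant: a 1.3-fold lower number from compound 1 to compound 3 (0.11 log units; within the scatter), so these two compounds are not separated and the exchange of linking group shows no measurable effect here. The step of a 3.7-fold lower number from compound 2 to compound 3 (0.57 log units; beyond the scatter) changes the ring and the linking group at once, and it ends at a number level with that of compound 1; among these three compounds, both that carry 2-chlorophenyl thus give lower numbers than the one that carries 3-methoxyphenyl, whichever linking group is present. Nothing available gives a measured reason for either step.

On these data alone, it remains open whether the sulfonyl would also match the carbonyl when paired with 3-methoxyphenyl, so the ring's part in this pattern rests on a single carbonyl pair and on the step to compound 3, which also changes the linking group. Also open, as far as these compounds go, is how a 3-chlorophenyl, a 2-methoxyphenyl or an unsubstituted phenyl would read on either linking group, and how a methylene would read in place of carbonyl or sulfonyl on this nitrogen.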